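The compounds below may be only part of what the source reports. "The series", "measured", "known", "first", "only" and "open" are said of these compounds alone.

In a functional assay on A549 cells (Homo sapiens) for inhibition, read by MTT assay, with a stated time of 24 h, tested at 5 uM (on this read-out higher numbers stand for more inhibition of growth at the one concentration tested and lower numbers for less inhibition of growth), compound 2, with the structure `CS(=O)(=O)c1ccc(-c2cnc3[nH]cc(-c4nnc(-c5ccc(F)cc5)o4)c(=O)c3c2)cc1`, gives 3.11%. Within the data shown here, only one other compound has been measured here: compound 1, `CS(=O)(=O)c1ccc(-c2cnc3[nH]cc(-c4nnc(-c5ccncc5)o4)c(=O)c3c2)cc1`, which in this assay gives 6.76%. The step from the first to the second, a number 3.7 percentage points lower from compound 1 to compound 2 (within the scatter), is within the scatter, so the two numbers cannot be told apart, and compound 2 stands simply as one of two low readings at this single concentration.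

Compound 3, `CS(=O)(=O)c1ccc(-c2cnc3[nH]cc(-c4nnc(-c5ccccc5)o4)c(=O)c3c2)cc1`, differs from compound 2 in one place: hydrogen in place of fluoro on an aromatic carbon. Among the measured compounds shown here, no measured step touches exactly this change; the only step available exchanged one whole aromatic group for another and itself stayed within the scatter. Nothing in the data therefore points to a step beyond the scatter in this assay, in either direction.

Compound 3 is accordingly expected to show about 5%, a step of a number 1.9 percentage points higher from compound 2 to compound 3 (within the scatter), with a likely range from -5% to 15%.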

Compound 3, percent growth inhibition at one concentration: 8.17%
Beside the measured number, compound 3's estimate is 3.2 percentage points below it, within the range that was stated.
By their numbers in this assay, from the lowest: compounds 2, 1 and 3 (each within the scatter of the next).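

In this assay, among these compounds, the result a number 5.1 percentage points higher from compound 2 to compound 3 (within the scatter) is the first direct reading of the fluoro itself, which sits para to a large group, and it shows that this single atom can be replaced by hydrogen without a change this read-out can separate from scatter. The result a number 1.4 percentage points higher from compound 1 to compound 3 (within the scatter) adds that phenyl and pyridin-4-yl cannot be told apart here either, so all three end groups give readings that sit within the scatter of one another. Nothing available here offers an explanation for these readings.

Still open, from the compounds shown here alone, is whether any other group on this aromatic carbon, such as an amine, a carboxylic acid or a longer chain, would move the reading beyond the scatter. Going by these compounds, it is also open how these compounds would behave at other concentrations, since only one was tested.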